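Furan-2-yl in place of methyl on compound 1's core

This account rests on a few compounds, and the source may have more. Where it says the series, first, only, none or still open, it means among the compounds named here.

Compound 1, `CC(=O)N1CCN(C=O)C1=S`: in a functional assay on MT4 cells (Homo sapiens) for antiproliferative activity, read by MTT assay (on this read-out lower numbers stand for stronger inhibition and higher numbers for weaker inhibition), compound 1 gives > 100000 nM, a limit of the assay.
Compound 2, `O=CN1CCN(C(=O)/C=C/c2ccccc2)C1=S`: compound 2 gives > 100000 nM, also a limit.
Compound 3, `CC(=O)N1CCN(C(C)=O)C1=S`: compound 3 gives > 100000 nM, again a limit.

Compound 1 therefore stands only at a limit, as do both other measured compounds: the limit of > 100000 nM in this assay, at which 3 of the 3 values shown sit. Among the compounds with values here, the single measured step that changes one place, a step that the two limits leave unreadable from compound 1 to compound 3, cannot be read for that reason. Compound 4, `O=CN1CCN(C(=O)c2ccco2)C1=S`, carries furan-2-yl in place of methyl on a carbonyl carbon. Within the data shown here, no measured step bears readably on this change, so no step in this assay of any direction beyond the scatter can be expected from the data. Compound 4 is expected to remain at the limit. The estimate for compound 4 is 100000 nM, between 30000 nM and 300000 nM, which would mean an expected a number no higher from compound 1 to compound 4 (the limit leaves the size open).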

Compound 4, half-maximal inhibitory concentration: 9000 nM
Estimate against measurement, compound 4: 11-fold (1.05 log units) above; the measured number lies below the stated range.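

With furan-2-yl in place of methyl on a carbonyl carbon, this assay shows an at least 11-fold lower number from compound 1 to compound 4 (1.04 log units; beyond the scatter), so this position can carry a change that brings a readable number. Compound 4 is the only compound shown with such a number, and the earlier step cannot be read: the limit of > 100000 nM in this assay, at which 3 of the 4 values shown sit. Compound 2 also differs from compound 4 at this place. Compound 2 gives > 100000 nM, a limit.

The compounds shown leave open whether phenyl or thiophen-2-yl at this place would give a comparable number. They also leave open what an amine on the furan ring would do.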